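The source may report more compounds than this note shows. Statements on the series, on what has been measured and on what is new or still open speak of the compounds shown alone.

Of the compounds shown here, two have so far been measured in an ADME assay on microsomes from liver (Rattus norvegicus) for metabolic stability, read by LC-MS, using NADPH, with a stated time of 60 min, tested at 10 uM; a lower number here means that less of the compound is left, a higher number that more of the compound is left. Compound 1 (`Fc1ccc(CN2CCC(NCCSC(c3ccc(F)cc3)c3ccc(F)cc3)CC2)cc1`) gives 70% in this assay. Compound 2 (`O=C(c1ccc(F)cc1)N1CCC(NCCSC(c2ccc(F)cc2)c2ccc(F)cc2)CC1`), which carries a (4-fluorophenyl)carbonyl in place of the 4-fluorobenzyl on the amine nitrogen in the ring, gives 24% in this assay. That is the lower of the two numbers, and the step of a number 46 percentage points lower from compound 1 to compound 2 (beyond the scatter) is large and lies beyond the scatter.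

Compound 3 (`O=C(c1ccc(F)cc1F)N1CCC(NCCSC(c2ccc(F)cc2)c2ccc(F)cc2)CC1`) has not yet been measured. It differs from compound 2 in one place: fluoro in place of hydrogen on an aromatic carbon. Cut one bond further out, the (4-fluorophenyl)carbonyl becomes a (2,4-difluorophenyl)carbonyl. Among the compounds with values here, the only measured step, from compound 1 to compound 2, exchanged a benzyl for a carbonyl; no measured step shows what an added fluoro on an aromatic ring does here, so there is no direct guide. For compound 3 a step of a number 4 percentage points higher from compound 2 to compound 3 (within the scatter) is expected in this assay, which stays within the scatter. Compound 3 is therefore estimated at 28%, with a range from 12% to 48%.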

Compound 3, percent of the compound remaining: 85%
Estimate against measurement, compound 3: 57 percentage points below; the measured number lies above the stated range.
By their numbers in this assay, from the lowest: compound 2; then compound 1; then compound 3.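

The step of a number 61 percentage points higher from compound 2 to compound 3 (beyond the scatter) shows that in this assay this aromatic carbon, ortho to a large group, matters a great deal: one added fluoro, a single heavy atom, turns the 4-fluorophenyl into a 2,4-difluorophenyl and produces a large change. Within the data shown here, the carbonyl on the ring nitrogen therefore does not by itself bring a low number, since with (2,4-difluorophenyl)carbonyl in place of 4-fluorobenzyl the result is a number 15 percentage points higher from compound 1 to compound 3 (beyond the scatter), a modest step in the opposite direction from the one the first pair showed. No measurement at hand bears on why one fluoro has so large an effect here.

The compounds shown leave open whether a chloro, a methyl or a methoxy on this same aromatic carbon would act as the fluoro does, or whether the result belongs to fluoro alone. They also leave open whether the same added fluoro would have a similar effect on the 4-fluorobenzyl of compound 1, where no carbonyl is present.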